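A few compounds are considered here, and "the series" means these few. Any claim that something is new, unique, unknown or untested is made for them only; others in the source may bear on it.

Measured in an ADME assay on HEK-293T cells (Homo sapiens) for inhibition, read by CCK-8 assay, with a stated time of 48 h, tested at 20 uM (a higher number here means more inhibition of growth at the concentration tested, a lower number less inhibition of growth), so far:
compound 1 `COc1ccc(Cc2nnc(NC(=O)/C(C#N)=C/c3ccccc3OS(=O)(=O)c3ccc(OC)cc3)s2)cc1` gives 30%
compound 2 `COc1ccc(S(=O)(=O)Oc2ccccc2/C=C(\C#N)C(=O)Nc2nnc(Cc3cccc4ccccc34)s2)cc1` gives 29%
compound 3 `Cc1ccc(Cc2nnc(NC(=O)/C(C#N)=C/c3ccccc3OS(=O)(=O)c3ccc(C)cc3)s2)cc1` gives 22%

Compound 3 at 22% lies within the scatter of both compound 1 and compound 2. Compound 4 `COc1ccc(S(=O)(=O)Oc2ccccc2/C=C(\C#N)C(=O)Nc2nnc(Cc3ccc(C)cc3)s2)cc1` keeps one 4-methylphenyl of compound 3 and changes the other, with (4-methylphenyl)sulfonyl becoming (4-methoxyphenyl)sulfonyl (methoxy in place of methyl on an aromatic carbon).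

For the measured compounds named here, no measured step isolates this change. The only one (a number 1 percentage points lower from compound 1 to compound 2 (within the scatter)) lies elsewhere in the molecule, and both of its compounds already carry the (4-methoxyphenyl)sulfonyl group. Compound 1 has methoxy at both places where compound 3 has methyl, and compound 1 at 30% stays within the scatter of compound 3 at 22%. Making only one of these two replacements is therefore expected to give no shift beyond the scatter in this assay. The expected step (a number 4 percentage points higher from compound 3 to compound 4 (within the scatter)) is small and upward. The estimate for compound 4 is 26% (expected range 16% to 36%).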

Compound 4, percent growth inhibition at one concentration: 28%
Beside the measured number, compound 4's estimate is 2 percentage points below it; the range from low to high includes it.
By their numbers in this assay, from the lowest: compounds 3, 4, 2 and 1 (each within the scatter of the next).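

In this assay, methoxy in place of methyl on the aromatic carbon of the sulfonyl-bearing ring now has its own reading, a number 6 percentage points higher from compound 3 to compound 4 (within the scatter), and the same exchange on the ring of the chain group reads a number 2 percentage points lower from compound 1 to compound 4 (within the scatter). With a number 1 percentage points lower from compound 2 to compound 4 (within the scatter), the group on the saturated chain carbon also gives no step beyond the scatter when 4-methylphenyl stands in place of naphthalen-1-yl, so none of the single changes among these compounds separates them in this assay. Nothing at hand bears on the reason for these readings.

As far as these compounds go, whether an amine or a carboxylic acid in place of methoxy at this position would give a step beyond the scatter remains open. The compounds shown also leave open how a longer chain in place of the saturated chain carbon would read.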